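The source may hold more compounds than are shown below. What is called first, only, known or untested is meant among the compounds shown, and "the series" means these compounds.

Working notes on the series. Compound 1 `COc1ccc(C(=O)CSc2nnc(-c3cc(OC)c(OC)c(OC)c3)n2-c2ccc(OC)cc2)cc1` gives > 60000 nM in a functional assay on HCT-116 cells (Homo sapiens) for inhibition, read by MTT assay, with a stated time of 48 h (on this read-out lower numbers stand for stronger inhibition and higher numbers for weaker inhibition), and this is a limit. Compound 2 `COc1ccc(-n2c(SCC(=O)C3CC3)nnc2-c2cc(OC)c(OC)c(OC)c2)cc1` gives > 60000 nM in this assay and this is also a limit. Compound 3 `CCOC(=O)CSc1nnc(-c2cc(OC)c(OC)c(OC)c2)n1-c1ccc(OC)cc1` gives > 60000 nM in this assay and this too is a limit. Among the measured compounds shown here, compound 3 therefore has no number to start from, and the whole series so far sits at one ceiling (the limit of > 60000 nM in this assay, at which 3 of the 3 values shown sit).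

Compound 4 `COc1ccc(-n2c(SCC(=O)Nc3ccc(Cl)cc3)nnc2-c2cc(OC)c(OC)c(OC)c2)cc1` carries (4-chlorophenyl)amino in place of the ethoxy of compound 3 on a carbonyl carbon ((4-chlorophenyl)amino in place of ethoxy on a carbonyl carbon).

The measured steps on this carbonyl carbon are a step that the two limits leave unreadable from compound 1 to compound 2 and a step that the two limits leave unreadable from compound 1 to compound 3 and also a step that the two limits leave unreadable from compound 2 to compound 3 so none of them supplies a size. Compound 1 has 4-methoxyphenyl on that carbonyl carbon and still gives > 60000 nM as a limit, so an aromatic ring there offers no ground for a large expected gain. The expected size of an at least 2.0-fold lower number from compound 3 to compound 4 (0.30 log units; that floor lies within the scatter) is modest at best and points toward lower numbers, though it may not be readable at all. In this assay the estimate for compound 4 is 30000 nM with an expected range from 6000 nM to 60000 nM and a report as a bare limit remains quite possible.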

Compound 4, half-maximal inhibitory concentration: > 60000 nM
Compound 4: no number, only a limit; the forecaster's own chance of this, stated with the estimate: 50%; at least 2.0-fold (0.30 log units) between middle value and limit.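

No new step can be read among compound 1, compound 2, compound 3 and compound 4, because each of them stops at the same limit: the limit of > 60000 nM in this assay, at which 4 of the 4 values shown sit.

The compounds shown leave open whether any group on this carbonyl carbon, or any change elsewhere on the shared core, gives an actual number in this assay.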